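Ethyl in Place of Chloro on a Weak Series

The source may hold more compounds than are shown below. What is called first, only, known or untested is meant among the compounds shown, and "the series" means these compounds.

Compound 1 `C=CCOc1ccc(C(=O)Nc2ccccn2)cc1` gives 61400 nM in an in vitro assay on HEK-tsA201 cells for antagonist activity at Neuronal acetylcholine receptor; alpha3/beta4 (Homo sapiens), read by fluorescence and calcium flux; on this read-out lower numbers stand for stronger inhibition and higher numbers for weaker inhibition.
Compound 2 `C=CCOc1ccc(C(=O)Nc2cccc(Cl)n2)cc1` gives > 100000 nM in this assay.

Two compounds share the core and differ only at one aromatic carbon. Compound 1 carries hydrogen there and sits at a high number in this assay, which means weak inhibition. Compound 2 carries chloro at that carbon; its value of > 100000 nM is a limit of the assay rather than a number, as set out in the limit of > 100000 nM in this assay, at which 1 of the 2 values shown sits. For the measured compounds named here, the one measured step, an at least 1.6-fold higher number from compound 1 to compound 2 (0.21 log units; that floor lies within the scatter), therefore only says that compound 2 is no stronger than compound 1.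

Compound 3 `C=CCOc1ccc(C(=O)Nc2cccc(CC)n2)cc1` is the next step: ethyl in place of chloro on an aromatic carbon. The change sits on an aromatic carbon of a six-membered aromatic ring with 1 nitrogen, next to the ring nitrogen and meta to a large group. Going by the values given here, no measured step covers ethyl at this position, so the expectation rests on compound 1 and compound 2 alone, both of which sit at the weak end. Compound 3 is expected to remain weak, and the step that the limit leaves unreadable from compound 2 to compound 3 is estimated as small. Compound 3 is thus estimated at 120000 nM, with a range from 40000 nM to 400000 nM.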

Compound 3, half-maximal inhibitory concentration: 27400 nM
Compound 3: the middle estimate sits 4.4-fold (0.64 log units) above what was measured, outside the stated range (below it).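

Ethyl in place of hydrogen on this aromatic carbon gives a 2.2-fold lower number from compound 1 to compound 3 (0.35 log units; beyond the scatter), so this position accepts a small carbon group with a modest gain in this assay, although compound 3, at 27400 nM, still stands for weak inhibition. Ethyl in place of chloro gives an at least 3.6-fold lower number from compound 2 to compound 3 (0.56 log units; beyond the scatter), which shows that the identity of the group at this carbon matters and not merely whether hydrogen has been replaced. The size of that second step remains a floor, since the value of compound 2 is a limit of the assay and not a number: the limit of > 100000 nM in this assay, at which 1 of the 3 values shown sits.

Whether the modest gain would grow, hold or vanish with a methyl group, a longer chain such as propyl, or an amine at this carbon stays open, since ethyl is the only carbon chain shown here. The rest of the shared core is also identical in all three compounds, so they cannot tell whether a change elsewhere would move the number further than any change at this position.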